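The compounds below may be only part of what the source reports. "The series", "measured", "known", "first", "only" and "open" are said of these compounds alone.

Among the compounds with values here, compound 1 `COc1ccccc1N1CCN(Cn2nc(-c3ccc4c(c3)OCCO4)oc2=S)CC1` is the only member of this pair with a number in a functional assay on HepG2 cells (Homo sapiens) for antiproliferative activity, read by MTT assay, with a stated time of 48 h; a lower number here means a stronger inhibitor, a higher number a weaker inhibitor; compound 1 gives 15500 nM. Compound 2 `COc1ccc(N2CCN(Cn3nc(-c4ccc5c(c4)OCCO5)oc3=S)CC2)cc1` reaches only the edge of what this assay reports: compound 2 gives > 50000 nM, which is a limit and not a number (the limit of > 50000 nM in this assay, at which 1 of the 2 values shown sits). Within the data shown here, the one measured step, an at least 3.2-fold higher number from compound 1 to compound 2 (0.50 log units; beyond the scatter), is thus itself only a lower bound. Compound 3 `S=c1oc(-c2ccc3c(c2)OCCO3)nn1CN1CCN(c2ccccn2)CC1` differs from compound 2 by pyridin-2-yl in place of 4-methoxyphenyl on an amine nitrogen in a ring. Among the measured compounds shown here, no measured step swaps a methoxyphenyl for a pyridinyl, so the step from compound 1 to compound 2 does not bear on the change directly; it shows only that the group on the ring nitrogen can shift the number beyond the scatter, with compound 2 at the limit. For compound 3 the number is therefore expected to remain near that limit, the step of an at least 1.2-fold lower number from compound 2 to compound 3 (0.09 log units; that floor lies within the scatter) being an uncertain guess. The estimate for compound 3 is 40000 nM, in the range 12000 nM to 100000 nM.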

Compound 3, half-maximal inhibitory concentration: 11400 nM
The estimate for compound 3 lay 3.5-fold (0.55 log units) above the measured number; measured number outside the range, below it.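

In this assay, pyridin-2-yl in place of 4-methoxyphenyl on the amine nitrogen in the ring gives an at least 4.3-fold lower number from compound 2 to compound 3 (0.64 log units; beyond the scatter), so a change at this position can bring the number back from the edge of the assay. Compound 2 stands at a limit and not a number, so that step is only a floor: the limit of > 50000 nM in this assay, at which 1 of the 3 values shown sits. Within the data shown here, the other new step, a 1.4-fold lower number from compound 1 to compound 3 (0.13 log units; within the scatter), does not separate pyridin-2-yl from 2-methoxyphenyl, which leaves 4-methoxyphenyl as the one group apart among the three.

The compounds shown do not tell whether the lower number of compound 3 follows from the ring nitrogen of pyridin-2-yl or from the absence of the methoxy group, a question an unsubstituted phenyl would address. Also open, on these data alone, is how a pyridin-4-yl or a benzyl group would read at this position.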